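The source may report more compounds than this note shows. Statements on the series, on what has been measured and on what is new or still open speak of the compounds shown alone.

In a functional assay on KB cells (Homo sapiens) for cytotoxicity, read by sulforhodamine B assay, with a stated time of 3 days (on this read-out higher numbers stand for an effect only at larger amounts of compound and lower numbers for an effect already at smaller amounts), compound 1 `Cc1coc(-c2ccc3c(c2O)CCCC3(C)C)c1C(=O)O` gives 4.7 uM, while compound 2 `Cc1coc(-c2ccc3c(c2O)CCCC3(C)C)c1CO` gives 22 uM, the higher of the two numbers. Compound 3 `CCOc1c(-c2occ(C)c2CO)ccc2c1CCCC2(C)C` differs from compound 2 as follows: ethyl in place of hydrogen on an oxygen on an aromatic ring, that is, hydroxy to ethoxy. Among the compounds with values here, the only measured step, a 4.7-fold higher number from compound 1 to compound 2 (0.67 log units; beyond the scatter), is a modest one that swaps carboxy for hydroxymethyl at another place, so it offers little guidance. Within the data shown here, no measured step alters this oxygen, and no clear direction can be derived. The expected change is therefore small, within the scatter: a 1.3-fold higher number from compound 2 to compound 3 (0.10 log units; within the scatter). For compound 3 the estimated value is 28 uM, with an expected range from 9 uM to 80 uM.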

Compound 3, concentration for half-maximal effect: 16.9 uM
Estimate against measurement, compound 3: 1.7-fold (0.22 log units) above; the range from low to high includes it.
By their numbers in this assay, from the lowest: compound 1; then compounds 3 and 2 (each within the scatter of the next).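

In this assay, the step of a 1.3-fold lower number from compound 2 to compound 3 (0.11 log units; within the scatter) stays within the scatter, so ethyl in place of hydrogen on this oxygen on an aromatic ring leaves the number in place. Compound 3 thus shows that, with hydroxymethyl present, a free hydroxy at this position is not required to keep this level of cytotoxicity. No measurement shown here accounts for this result. From the compounds shown here alone, whether a longer chain or an amine would be tolerated here remains open. So does whether hydroxy to ethoxy would behave the same way alongside the carboxy group of compound 1.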